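The source may report more compounds than this note shows. Statements on the series, on what has been measured and on what is new or still open speak of the compounds shown alone.

In an ADME assay on HFF cells (Homo sapiens) for cytotoxicity, read by neutral red uptake (on this read-out lower numbers stand for higher toxicity in this test and higher numbers for lower toxicity in this test), compound 1 `Nc1nc2c(ncn2/C=C2\C[C@@H]2[C@@H](O)CO)c(=O)[nH]1` gives > 300000 nM, which is a limit of the assay and not a number. Compound 2 `Nc1ncnc2c1ncn2/C=C1\C[C@H]1[C@H](O)CO` gives 194000 nM, a measured number in the same test. Compound 3 `Nc1nc2c(ncn2/C=C2/C[C@H]2[C@H](O)CO)c(=O)[nH]1` has the same atoms and bonds as compound 1 and differs only in configuration as drawn: the two compounds have the same atoms and bonds and differ only in configuration as drawn: 3 of 3 stereo elements differ; a stereocentre at a saturated ring carbon is drawn S in compound 1 and R in compound 3; a stereocentre at a saturated chain carbon is drawn R in compound 1 and S in compound 3; a double bond is drawn E in compound 1 and Z in compound 3. For the measured compounds named here, no measured pair shows what such a change does in this assay, so no step beyond the scatter is expected, and any shift would lean toward the value of compound 2 at 194000 nM. The expected change is an at least 1.1-fold lower number from compound 1 to compound 3 (0.06 log units; that floor lies within the scatter). For compound 3 the estimated value is 260000 nM, with an expected range of 120000 nM to 450000 nM.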

Compound 3, half-maximal cytotoxic concentration: > 300000 nM
Compound 3: a limit, no number; the forecaster's own chance of this, stated with the estimate: 55%; middle value at least 1.1-fold (0.06 log units) from the limit.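

In this assay, for the compounds shown here, compound 3 gives > 300000 nM, a limit and not a number, as compound 1 also does, so no step between the two can be read. From the compounds shown here alone, what their difference in configuration does in this assay remains open.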